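The compounds below may be only part of what the source reports. "The series", "measured", "known", "first", "only" and "open" are said of these compounds alone.

Compound 1 `COc1cc(-c2cccc3nc(-c4ccc(Br)cc4)oc23)cc(OC)c1OC`: > 25000 nM (a limit)
Compound 2 `COc1cc(-c2cccc3nc(-c4ccc(C)cc4)oc23)cc(OC)c1OC`: 680 nM

Among the compounds with values here, in a functional assay on A549 cells (Homo sapiens) for antiproliferative activity, read by MTT assay, with a stated time of 48 h (on this read-out higher numbers stand for weaker inhibition and lower numbers for stronger inhibition), compound 2 gives 680 nM, the only actual number so far. Compound 1 gives > 25000 nM, which is a limit of the assay. Compound 3 `COc1cc(-c2cccc3nc(-c4cccc(O)c4)oc23)cc(OC)c1OC` keeps the shared core and differs from compound 2 in one place: 3-hydroxyphenyl in place of 4-methylphenyl on an aromatic carbon. This puts 3-hydroxyphenyl in place of 4-methylphenyl on an aromatic carbon. Within the data shown here, one measured step bears on this part of the molecule: an at least 36-fold lower number from compound 1 to compound 2 (1.56 log units; beyond the scatter). Among the measured compounds shown here, that large step shows that a single exchange on this phenyl group can move the number strongly, but no measured compound carries a hydroxy group. A moderate step toward weaker inhibition in this assay is therefore expected, with wide uncertainty. The estimated change is a 2.2-fold higher number from compound 2 to compound 3 (0.34 log units; beyond the scatter). For compound 3 the estimated value is 1500 nM, expected to fall between 200 nM and 12000 nM.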

Compound 3, half-maximal inhibitory concentration: 2000 nM
Beside the measured number, compound 3's estimate is 1.3-fold (0.12 log units) below it, and the stated range covers the measured number.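

In this assay, the exchange gives a 2.9-fold higher number from compound 2 to compound 3 (0.47 log units; beyond the scatter). Within the data shown here, this is the first hydroxy group at this position, and with 3-hydroxyphenyl the compound still gives a measured number, although weaker than with 4-methylphenyl. The other comparison gives an at least 12-fold lower number from compound 1 to compound 3 (1.09 log units; beyond the scatter), so two of the three aryl groups shown give a measured number, while the value for compound 1 is only a limit, which sets a minimum on that step: the limit of > 25000 nM in this assay, at which 1 of the 3 values shown sits.

Compound 3 differs from compound 2 in both the substituent and where it sits on the phenyl group, so the compounds shown cannot separate these two changes. On these data alone, it also stays open how 4-hydroxyphenyl, 3-methylphenyl, or a phenyl group carrying an amine or a carboxylic acid would read in this assay.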